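The source may report more compounds than this note shows. Statements on the series, on what has been measured and on what is new or still open speak of the compounds shown alone.

Compound 1 `CCOC(=O)C1=Cc2ccccc2OC1(OCc1cn(-c2ccc(F)cc2)nn1)C(F)(F)F`: 8900 nM
Compound 2 `CCOC(=O)C1=Cc2ccccc2OC1(OCc1cc(-c2ccc(F)cc2F)no1)C(F)(F)F`: > 150000 nM
Compound 3 `CCOC(=O)C1=Cc2ccccc2OC1(OCc1cn(-c2cccc(OC)c2)nn1)C(F)(F)F`: > 150000 nM

For the measured compounds named here, in a functional assay on DU-145 cells (Homo sapiens) for inhibition, read by MTT assay, with a stated time of 24 h (on this read-out lower numbers stand for stronger inhibition and higher numbers for weaker inhibition), compound 1 gives 8900 nM, the only actual number among the three. For compound 2 the value > 150000 nM is a limit of the assay, not a number. For compound 3 the value > 150000 nM is likewise a limit. Changing the aromatic group on the ring nitrogen gave an at least 16-fold higher number from compound 1 to compound 3 (1.22 log units; beyond the scatter), with two of the three values sitting at the limit of > 150000 nM in this assay, at which 2 of the 3 values shown sit. Compound 4 `CCOC(=O)C1=Cc2ccccc2OC1(OCc1cn(CC(=O)NC2CCCCC2)nn1)C(F)(F)F` differs from compound 1 by (cyclohexylcarbamoyl)methyl in place of 4-fluorophenyl on an aromatic nitrogen. Going by the values given here, the only measured change at this position weakened inhibition beyond the scatter, so a weaker number is expected for compound 4 as well, possibly at the limit. Compound 4 is therefore estimated at 50000 nM, between 8000 nM and 150000 nM, a step of a 5.6-fold higher number from compound 1 to compound 4 (0.75 log units; beyond the scatter) expected.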

Compound 4, half-maximal inhibitory concentration: 10200 nM
Compound 4: middle estimate off by 4.9-fold (0.69 log units), on the high side, within the range that was stated.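

On the aromatic nitrogen, a group without an aromatic ring can stand in for 4-fluorophenyl: in this assay, (cyclohexylcarbamoyl)methyl gives a 1.1-fold higher number from compound 1 to compound 4 (0.06 log units; within the scatter). Compound 3 gives > 150000 nM, which is a limit of the assay and not a number. The weak result with 3-methoxyphenyl therefore does not hold for every new group at this position: an at least 14-fold lower number from compound 3 to compound 4 (1.16 log units; beyond the scatter).

Which part of the new group counts, the amide or the cyclohexyl ring, stays open. A simple hexyl chain or a carboxylic acid at this nitrogen could separate the two.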